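Lengthening the side chain in the sulfonamide amide series

This account rests on a few compounds, and the source may have more. Where it says the series, first, only, none or still open, it means among the compounds named here.

For the measured compounds named here, compound 3 `CCC(C(=O)Nc1cccc(Cl)c1)N(c1ccccc1Cl)S(C)(=O)=O` carries the highest of the two single numbers so far: in a functional assay on HEK293 cells for positive allosteric modulation of metabotropic glutamate receptor 5 (Rattus norvegicus), read by fluorescence and calcium flux (on this read-out lower numbers stand for an effect already at smaller amounts and higher numbers for an effect only at larger amounts of compound), compound 3 gives 3300 nM. Going by the values given here, its nearest neighbour, compound 2 `CC(C(=O)Nc1cccc(Cl)c1)N(c1ccccc1Cl)S(C)(=O)=O`, gives 68 nM, and the step of a 49-fold higher number from compound 2 to compound 3 (1.69 log units; beyond the scatter) is the only one-place change measured. Compound 1 `CS(=O)(=O)N(CC(=O)Nc1ccc(F)cn1)c1ccccc1Cl` gives 3720 nM; 3720 nM (2 entries), within scatter of compound 3. Compound 4 `CCCC(C(=O)Nc1cccc(Cl)c1)N(c1ccccc1Cl)S(C)(=O)=O` differs from compound 3 by methyl in place of hydrogen on a saturated chain carbon, three bonds along the chain from a carbonyl carbon and a sulfonamide nitrogen. The one bearing step is the large loss from compound 2 to compound 3 on the same chain, two bonds along from the carbonyl carbon; whether a further methyl repeats it is not shown. Expected for compound 4 is a step of a 1.8-fold higher number from compound 3 to compound 4 (0.26 log units; within the scatter), a modest rise or none beyond the scatter. The estimate for compound 4 is 6000 nM, ranging from 1500 nM to 25000 nM.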

Compound 4, half-maximal effective concentration: > 10000 nM
Compound 4: only a limit was reported (the forecaster's own chance of this, stated with the estimate: 20%); middle value at least 1.6-fold (0.22 log units) away from the limit.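

Ethyl to propyl on this saturated chain carbon brings a further loss beyond the scatter, with an at least 3.0-fold higher number from compound 3 to compound 4 (0.48 log units; beyond the scatter), so the drop does not end with the first added methyl. Measured from the methyl of compound 2, the change to propyl gives an at least 140-fold higher number from compound 2 to compound 4 (2.16 log units; beyond the scatter), and none of compound 2, compound 3 or compound 4 goes against the rise along this chain. The entry for compound 4 in this assay is a limit, not a number: the limit of > 10000 nM in this assay, at which 1 of the 4 values shown sits.

On these data alone, the full size of the loss at compound 4 stays open. So does whether a cyclopropyl or a hydroxymethyl group on this carbon would keep the number near that of compound 2.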